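Swapping the Aryl Urea Group for Cyclohexyl

A few compounds are considered here, and "the series" means these few. Any claim that something is new, unique, unknown or untested is made for them only; others in the source may bear on it.

In a functional assay on A549 cells (Homo sapiens) for antiproliferative activity, read by MTT assay, with a stated time of 72 h (a lower number here means a stronger inhibitor, a higher number a weaker inhibitor), compound 1 `O=C(Nc1ccc(Nc2nccc(NC3CCCC3)n2)cc1)Nc1ccc(Cl)c(C(F)(F)F)c1` gives 5880 nM. Compound 3 `O=C(Nc1ccc(Nc2nccc(Nc3cccc(Cl)c3)n2)cc1)Nc1ccc(Cl)c(C(F)(F)F)c1` gives 8050 nM, and a 1.4-fold higher number from compound 1 to compound 3 (0.14 log units; within the scatter) leaves the two level. Compound 2 `O=C(Nc1ccc(Nc2nccc(Nc3ccccc3)n2)cc1)Nc1ccc(Cl)c(C(F)(F)F)c1` reads > 50000 nM, which is a limit of the assay. Compound 1 therefore shares the best measured position with compound 3.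

Compound 4 `O=C(Nc1ccc(Nc2nccc(NC3CCCC3)n2)cc1)NC1CCCCC1` keeps the cyclopentyl group of compound 1 and has cyclohexyl in place of 4-chloro-3-(trifluoromethyl)phenyl on an amide-type nitrogen. Among the compounds with values here, no measured step touches this group, so the guidance is indirect and points both ways. Phenyl in place of cyclopentyl on a nitrogen on an aromatic ring gave an at least 8.5-fold higher number from compound 1 to compound 2 (0.92 log units; beyond the scatter), which favours the non-aromatic ring. Chloro in place of hydrogen on an aromatic carbon gave an at least 6.2-fold lower number from compound 2 to compound 3 (0.79 log units; beyond the scatter), which suggests that losing chloro may cost activity. Weighing these, a modest rise in this assay is expected, with a 3.1-fold higher number from compound 1 to compound 4 (0.49 log units; beyond the scatter) as the estimated step. For compound 4 the expected value is 18000 nM, with an estimated range of 6000 nM to 50000 nM.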

Compound 4, half-maximal inhibitory concentration: 5320 nM
The estimate for compound 4 lay 3.4-fold (0.53 log units) above the measured number; the measured number lies below the stated range.
By their numbers in this assay, from the lowest: compounds 4, 1 and 3 (each within the scatter of the next). At a limit, above all of these: compound 2.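

The earlier compounds shown here all carried 4-chloro-3-(trifluoromethyl)phenyl on the amide-type nitrogen, so they said nothing about this position. With cyclohexyl in place of that group, this assay gives a 1.1-fold lower number from compound 1 to compound 4 (0.04 log units; within the scatter), so at this reading the aromatic group with its chlorine and fluorine atoms can give way to a smaller non-aromatic carbon ring and the two compounds stay level. Nothing measured here accounts for this result.

As far as these compounds go, it remains open whether any group on this nitrogen can move the number beyond the scatter, for example a straight hexyl chain or a ring carrying an amine. From the compounds shown here alone, it is also open whether cyclohexyl here would read the same with 3-chlorophenyl in place of cyclopentyl on the other nitrogen.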